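Two limits, and a phenyl in place of pentyl

The source may report more compounds than this note shows. Statements on the series, on what has been measured and on what is new or still open speak of the compounds shown alone.

Measured so far in a functional assay on HCT-116 cells (Homo sapiens) for antiproliferative activity, read by MTT assay, with a stated time of 48 h (a lower number here means a stronger inhibitor, a higher number a weaker inhibitor), as follows
- Compound 1 `CCCCCC(CCO)n1cnc2c(Cl)ncnc21` gives > 50000 nM as a limit
- Compound 2 `C=C(CO)C(CCCCC)n1cnc2c(Cl)ncnc21` gives > 50000 nM as a limit

Compound 2 therefore has no number, only its limit of > 50000 nM in this read-out. The evidence so far is the limit of > 50000 nM in this assay, at which 2 of the 2 values shown sit, and nothing more. Among the compounds with values here, the only measured step is a step that the two limits leave unreadable from compound 1 to compound 2 and it gives no size to carry forward.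

Compound 3 `C=C(CO)C(c1ccccc1)n1cnc2c(Cl)ncnc21` brings a new change, phenyl in place of pentyl on a saturated chain carbon bound to an aromatic nitrogen and a double-bonded chain carbon with phenyl in place of pentyl on a saturated chain carbon bound to an aromatic nitrogen and a double-bonded chain carbon. The expectation rests on compound 2 at > 50000 nM as a limit alone. The expected result is an at least 1.2-fold lower number from compound 2 to compound 3 (0.09 log units; that floor lies within the scatter) in this assay with only a tentative lean towards stronger inhibition. Compound 3 is estimated at 40000 nM with an expected range from 10000 nM to 100000 nM and another report as a limit remains likely.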

Compound 3, half-maximal inhibitory concentration: 33300 nM
Compound 3: the middle estimate sits 1.2-fold (0.08 log units) above what was measured; measured number inside the range.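

Phenyl in place of pentyl on a saturated chain carbon bound to an aromatic nitrogen and a double-bonded chain carbon gives the first number rather than a limit in this assay, with an at least 1.5-fold lower number from compound 2 to compound 3 (0.17 log units; that floor lies within the scatter). That step is a floor set by the limit of compound 2, not a measured size, and the floor itself lies within the scatter. Most of the series still rests on limits: the limit of > 50000 nM in this assay, at which 2 of the 3 values shown sit.

The compounds shown leave open whether a benzyl group or a 4-fluorophenyl group at this place would move the number away from compound 3 at 33300 nM. Also open, on these data alone, is what the 1-(hydroxymethyl)ethenyl group contributes alongside phenyl, and what an amine in place of its hydroxyl would give.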